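Aryl amines versus azetidine on the quinone core

The source may report more compounds than this note shows. Statements on the series, on what has been measured and on what is new or still open speak of the compounds shown alone.

Measured so far:
compound 1 `O=C1C=C(N2CCC2)C(=O)c2c1nc1n2[C@H]2OC[C@@H](O)[C@H]2OC1` — > 16000 nM
compound 2 `CCc1ccc(NC2=CC(=O)c3c(nc4n3[C@H]3OC[C@@H](O)[C@H]3OC4)C2=O)cc1` — 1110 nM
compound 3 `O=C1C(N2CCC2)=CC(=O)c2c1nc1n2[C@H]2OC[C@@H](O)[C@H]2OC1` — > 16000 nM

In a functional assay on MGC-803 cells (Homo sapiens) for inhibition, read by sulforhodamine B assay (on this read-out higher numbers stand for weaker inhibition and lower numbers for stronger inhibition), compound 1 gives only the limit > 16000 nM, not a number. Compound 3 likewise stops at the limit > 16000 nM. Among the measured compounds shown here, compound 2 is the one member with a measured number, 1110 nM. Two of the three values thus share the limit noted in the limit of > 16000 nM in this assay, at which 2 of the 3 values shown sit.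

Compound 4 `Cc1ccc(NC2=CC(=O)c3nc4n(c3C2=O)[C@H]2OC[C@@H](O)[C@H]2OC4)cc1C` is derived from compound 1 by the change ((3,4-dimethylphenyl)amino in place of azetidin-1-yl on a double-bonded ring carbon). For the measured compounds named here, the one measured step of this kind is an at least 14-fold higher number from compound 2 to compound 3 (1.15 log units; beyond the scatter), the same swap run in the opposite direction: removing the aryl amine in favour of azetidin-1-yl pushed the value off the top of the range. Reversing it on compound 1 should therefore bring the number down by a large margin, though compound 4 carries its aryl amine on a different double-bonded ring carbon than compound 2, so the analogy is not exact.

Compound 4 is expected at 1500 nM (range 500 nM to 6000 nM), which is the estimated step of an at least 10-fold lower number from compound 1 to compound 4 (1.02 log units; beyond the scatter).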

Compound 4, half-maximal inhibitory concentration: 860 nM
Estimate against measurement, compound 4: 1.7-fold (0.24 log units) above; the measured number falls inside the stated range.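

In this assay, the swap between azetidin-1-yl and (3,4-dimethylphenyl)amino now has a reading on a second double-bonded ring carbon: an at least 18-fold lower number from compound 1 to compound 4 (1.26 log units; beyond the scatter). Together with an at least 14-fold higher number from compound 2 to compound 3 (1.15 log units; beyond the scatter), which runs in the opposite direction with a different aryl amine, this puts the aryl amine at the lower number on both ring carbons shown, and no compound here goes against it. The full size of each step stays unread, as each rests on a limit of the assay: the limit of > 16000 nM in this assay, at which 2 of the 4 values shown sit.

As far as these compounds go, whether the choice of ring carbon matters for an aryl amine stays open, as compound 2 and compound 4 differ in more than one place. Also open, from the compounds shown here alone, is how a morpholine on either ring carbon, or a carboxylic acid on the aryl ring, would read.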